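Trifluoromethyl in place of nitro: working notes

This account rests on a few compounds, and the source may have more. Where it says the series, first, only, none or still open, it means among the compounds named here.

compound 1 `COc1cc(OC)c(C(=O)/C=C/c2ccc(O)cc2)c(OC)c1` gives 40600 nM
compound 2 `COc1cc(OC)c(C(=O)/C=C/c2ccc([N+](=O)[O-])cc2)c(OC)c1` gives 8000 nM

Both values come from a functional assay on HeLa cells (Homo sapiens) for inhibition, read by MTT assay, with a stated time of 72 h; on this read-out lower numbers stand for stronger inhibition and higher numbers for weaker inhibition. Among the compounds with values here, of the two numbers so far, compound 2 holds the lower, at 8000 nM, and its only neighbour is compound 1. The next structure is compound 3 `COc1cc(OC)c(C(=O)/C=C/c2ccc(C(F)(F)F)cc2)c(OC)c1`, which shares the core of compound 2. The change is trifluoromethyl in place of nitro on an aromatic carbon, para to a large group.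

Within the data shown here, one measured step bears on this, at the same place on the molecule: a 5.1-fold lower number from compound 1 to compound 2 (0.71 log units; beyond the scatter), with nitro in place of hydroxy. That step is modest, though beyond the scatter. Among the measured compounds shown here, no measured compound carries trifluoromethyl, so the data offer no direct guide to this group, and the single step gives only a rough scale. A smaller change than that one is expected in this assay, with the number drifting slightly upward. The expected step is a 1.4-fold higher number from compound 2 to compound 3 (0.14 log units; within the scatter), which may not clear the scatter. For compound 3 the estimated value is 11000 nM, with an expected range of 4500 nM to 26000 nM.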

Compound 3, half-maximal inhibitory concentration: 5100 nM
Beside the measured number, compound 3's estimate is 2.2-fold (0.33 log units) above it; measured number inside the range.
By their numbers in this assay, from the lowest: compounds 3 and 2 (each within the scatter of the next); then compound 1.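

Trifluoromethyl in place of nitro, on an aromatic carbon para to a large group, gives a 1.6-fold lower number from compound 2 to compound 3 (0.20 log units; within the scatter) in this assay, so the two groups cannot be told apart here, although nitro counts 2 hydrogen-bond acceptors and trifluoromethyl 0. The lower numbers at this position are therefore not tied to nitro alone: a second replacement of hydroxy gives an 8.0-fold lower number from compound 1 to compound 3 (0.90 log units; beyond the scatter), a modest step beyond the scatter, and it lands level with compound 2 rather than with compound 1. Nothing measured here accounts for why compound 1 stands apart from the other two, or for why these two different groups read alike.

Going by these compounds, with only hydroxy, nitro and trifluoromethyl at this place, it remains open whether an amine, a carboxylic acid, a methoxy group or a bare hydrogen would read like compound 1 or like the pair of compound 2 and compound 3. Also open, on these data alone, is whether the same exchange holds at other places on this aromatic ring, or on a different core, and whether it holds in cells other than those of this single assay.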